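Notes on an ethyl-imidazole series: compound 3 to compound 4

A few compounds are considered here, and "the series" means these few. Any claim that something is new, unique, unknown or untested is made for them only; others in the source may bear on it.

Measured so far in a functional assay on CHO cells for antagonist activity at Orexin/Hypocretin receptor type 1 (Homo sapiens), read by FLIPR and calcium flux; a lower number here means a stronger inhibitor, a higher number a weaker inhibitor:
compound 1 `CCc1nc(Cl)c2n1CCN([C@@H](C(=O)NC)c1ccccc1)[C@H]2COc1ccc(C(F)(F)F)cc1`: 431 nM
compound 2 `CCc1nc(Cl)c2n1CCN([C@@H](C(=O)NC)c1ccccc1)[C@H]2CCc1ccc(C(F)(F)F)cc1F`: 45 nM
compound 3 `CCc1nc(Cl)c2n1CCN([C@@H](C(=O)NC)c1ccccc1)[C@H]2CCc1cc(F)c(C(F)(F)F)cc1F`: 32 nM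

Compound 3 gives the lowest number of the three, but its step to compound 2 is within the scatter, so the two cannot be ordered; only compound 1 is clearly set apart, as the step of a 9.6-fold lower number from compound 1 to compound 2 (0.98 log units; beyond the scatter) shows. The step of a 1.4-fold lower number from compound 2 to compound 3 (0.15 log units; within the scatter) adds a fluoro on an aromatic carbon without moving the number beyond the scatter.

Compound 4 `CCc1nc(Cl)c2n1CCN([C@@H](C(=O)NC)c1ccccc1)[C@H]2CCc1ccc(F)c(F)c1F` carries 2,3,4-trifluorophenyl in place of 2,5-difluoro-4-(trifluoromethyl)phenyl on a saturated chain carbon, two bonds along the chain from a saturated ring carbon. Neither measured step covers this change: the step from compound 1 to compound 2 swaps the linking atom and the step from compound 2 to compound 3 only adds a fluoro, while here the trifluoromethyl leaves and a third fluoro enters. Within the data shown here, all three measured compounds keep a trifluoromethyl on that ring, so its removal has no precedent, and the nearest guide is the small step of a 1.4-fold lower number from compound 2 to compound 3 (0.15 log units; within the scatter) for fluoro changes alone. A modest weakening is expected, in this assay roughly a 3.4-fold higher number from compound 3 to compound 4 (0.54 log units; beyond the scatter), with wide uncertainty. Compound 4 is therefore estimated at 110 nM, between 30 nM and 400 nM.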

Compound 4, half-maximal inhibitory concentration: 30 nM
Compound 4: the middle estimate sits 3.7-fold (0.56 log units) above what was measured; measured number inside the range.
By their numbers in this assay, from the lowest: compounds 4, 3 and 2 (each within the scatter of the next); then compound 1.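

In this assay, among these compounds, 2,3,4-trifluorophenyl takes the place of a ring bearing trifluoromethyl without separating from the earlier compounds: a 1.1-fold lower number from compound 3 to compound 4 (0.03 log units; within the scatter) and a 1.5-fold lower number from compound 2 to compound 4 (0.18 log units; within the scatter) both remain within the scatter. Compound 4, the only compound shown without trifluoromethyl on that ring, therefore cannot be ordered against compound 2 or compound 3, while a 14-fold lower number from compound 1 to compound 4 (1.16 log units; beyond the scatter) keeps compound 1 clearly apart from it. Nothing available here accounts for this result.

The compounds shown leave open whether an unsubstituted phenyl, or a ring carrying an amine or a carboxylic acid, would read like compound 4 at this position. They also leave open how a longer chain in place of the present one, on the saturated ring carbon, would read in this assay for the same 2,3,4-trifluorophenyl.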